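Trimming the Side Chain of a Weak Inhibitor

The source may report more compounds than this note shows. Statements on the series, on what has been measured and on what is new or still open speak of the compounds shown alone.

Measured so far:
Compound 1, `Cc1nc(Cc2ccccc2)n2c(O)nncc12`, for which a functional assay for inhibition, with Homo sapiens as the target (a higher number here means a weaker inhibitor, a lower number a stronger inhibitor), gives only a limit, > 48000 nM.
Compound 2, `CCCc1nc(C)c2cnnc(O)n12`, which in this assay gives 56800 nM.

For the measured compounds named here, compound 2 holds the only real number in this assay, the other value shown is a limit of the assay and not a number. Going by the values given here, the single measured step, a step that the limit leaves unreadable from compound 1 to compound 2, cannot be sized because the limit of > 48000 nM in this assay, at which 1 of the 2 values shown sits, hides one end of it. Both compounds share the same core, so nothing measured yet says how strongly changes on that chain move the read-out.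

Compound 3, `Cc1ncn2c(O)nncc12`, differs from compound 2 by hydrogen in place of propyl on an aromatic carbon. Among the compounds with values here, this touches the same chain that the measured step altered, but that step gives no readable size, so no measured step sets a scale here. The expected step of a 1.4-fold higher number from compound 2 to compound 3 (0.15 log units; within the scatter) is therefore put near the scatter or a little toward weaker inhibition. Compound 3 is accordingly estimated at 80000 nM, with a range from 25000 nM to 250000 nM, and a fair chance that only a limit is reported.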

Compound 3, half-maximal inhibitory concentration: > 48000 nM
Compound 3: only a limit was reported; the forecaster's own chance of this, stated with the estimate: 50%; the middle value is on the limit's open side.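

Like compound 1, compound 3 gives only a limit of the assay and not a number, so the change from compound 2 to compound 3 has no readable size because one end of it stays hidden: the limit of > 48000 nM in this assay, at which 2 of the 3 values shown sit.

The compounds shown leave open how much the chain on the shared core moves the read-out, or whether it moves it at all.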